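The compounds below may be only part of what the source reports. "The series", "measured", "known", "first", "only" and "open" are said of these compounds alone.

Measured compounds, inhibition in an assay on isolated protein for inhibition of Ca2+/calmodulin-dependent protein kinase II (CaM kinase II) (Rattus norvegicus), tested at 30 uM; on this read-out lower numbers stand for less inhibition and higher numbers for more inhibition at the one concentration tested (going by the name of the read-out):
- compound 1, `c1ccc(Sc2ncnc3[nH]cnc23)cc1`: 0%
- compound 2, `Fc1ccc(Sc2ncnc3[nH]cnc23)cc1`: 0%
- compound 3, `Fc1ccc(Sc2[nH]cnc3nccc2-3)cc1`: 3%

Compound 2 stands level with compound 1, the two together being the lowest numbers of the three; compound 3 lies higher by an amount that is within the scatter, so no order among the three can be read from these numbers.

The unmeasured compound 4, `Cn1cnc2c(Sc3ccc(F)cc3)ncnc21`, differs from compound 2 by methyl in place of hydrogen on an aromatic nitrogen; the methyl enters on an aromatic nitrogen of a five-membered aromatic ring with 2 nitrogen, part of a fused or bridged system of two rings. Among the compounds with values here, no measured step covers a change on a ring nitrogen of this core. Within the data shown here, the only step known, no change at the digits printed from compound 1 to compound 2 (within the scatter), concerns fluoro in place of hydrogen on an aromatic carbon and is flat. With every measured number sitting at or near zero and no step beyond the scatter anywhere in the set, the expectation for this assay is a step from compound 2 to compound 4 of about a number 2 percentage points higher from compound 2 to compound 4 (within the scatter), that is, none beyond the scatter. Compound 4 is therefore estimated at 2%, within a range from 0% to 14%.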

Compound 4, a percentage reported as inhibition, at one concentration (the size of the read-out at that concentration, not a potency): 5%
The estimate for compound 4 lay 3 percentage points below the measured number, and the stated range covers the measured number.
By their numbers in this assay, from the lowest: compounds 1, 2, 3 and 4 (each within the scatter of the next).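

In this assay, within the data shown here, methyl in place of hydrogen on the aromatic nitrogen of the five-membered ring gives a number 5 percentage points higher from compound 2 to compound 4 (within the scatter), the first change at this ring nitrogen. Compound 1 and compound 2 carry only hydrogen there, and the step shows that a methyl at this position leaves the number within the scatter, so the change is flat, like the fluoro step on the aromatic carbon. Nothing measured on these compounds speaks to the reason for this result.

On these data alone, whether a larger group on the same nitrogen, such as a benzyl, a longer chain or a chain ending in an amine or a carboxylic acid, would give a step beyond the scatter remains open. As far as these compounds go, with all four numbers close to zero, it also remains open whether this nitrogen matters at all for the read-out.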